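A few compounds are considered here, and "the series" means these few. Any claim that something is new, unique, unknown or untested is made for them only; others in the source may bear on it.

Working notes on the series. All three measured members share one core and differ only in the aryl group on the carbon with a double bond to nitrogen. Compound 1 `CCCSc1nc(N/N=C/c2cccnc2)c2nnn(Cc3ccccc3)c2n1` carries pyridin-3-yl there; in a functional assay on ECa-109 cells (Homo sapiens) for antiproliferative activity, read by MTT assay, with a stated time of 72 h (on this read-out lower numbers stand for stronger inhibition and higher numbers for weaker inhibition), compound 1 gives > 64000 nM, which is a limit of the assay and not a number. Compound 2 `CCCSc1nc(N/N=C/c2ccc(Cl)cc2)c2nnn(Cc3ccccc3)c2n1` carries 4-chlorophenyl; in this assay compound 2 gives > 64000 nM, again a limit. Compound 3 `CCCSc1nc(N/N=C/c2cccs2)c2nnn(Cc3ccccc3)c2n1` carries thiophen-2-yl; in this assay compound 3 gives > 64000 nM, likewise a limit. Compound 3 therefore stands where the other two stand: at the limit, with no number of its own. The steps between the measured compounds are a step that the two limits leave unreadable from compound 1 to compound 2, a step that the two limits leave unreadable from compound 1 to compound 3 and a step that the two limits leave unreadable from compound 2 to compound 3; none of them has a readable size, because of the limit of > 64000 nM in this assay, at which 3 of the 3 values shown sit.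

Compound 4 `CCCSc1nc(N/N=C/c2c[nH]c3ccccc23)c2nnn(Cc3ccccc3)c2n1` is not yet measured. It differs from compound 3 in one place: 1H-indol-3-yl in place of thiophen-2-yl on a carbon with a double bond to nitrogen. The three measured steps bear on this change only in showing that swapping the aryl group among three small heteroaryl or aryl groups never brought a value below the limit; they give no size to carry over. Compound 4 is expected to sit at or near the same limit, a step that the limit leaves unreadable from compound 3 to compound 4 at most. The estimate for compound 4 in this assay is 100000 nM, with a range from 20000 nM to 500000 nM.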

Compound 4, half-maximal inhibitory concentration: 8690 nM
Compound 4: middle estimate off by 12-fold (1.06 log units), on the high side; the measured number lies below the stated range.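

The carbon with a double bond to nitrogen is now seen to be a position that can move the read-out in this assay: 1H-indol-3-yl there gives an at least 7.3-fold lower number from compound 3 to compound 4 (0.86 log units; beyond the scatter) and an at least 7.3-fold lower number from compound 2 to compound 4 (0.86 log units; beyond the scatter) and also an at least 7.3-fold lower number from compound 1 to compound 4 (0.86 log units; beyond the scatter) in the same assay. Among these compounds, compound 4 thus holds the only value that is a number, and the change that produces it adds a six-membered aromatic ring of carbon only and a hydrogen-bond donor, neither of which occurs in the three groups before it. The steps among compound 1, compound 2 and compound 3 still cannot be read, and the three steps to compound 4 give only a lower bound on their size, because of this: the limit of > 64000 nM in this assay, at which 3 of the 4 values shown sit.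

The compounds shown leave open whether the drop goes with the added six-membered ring or with the hydrogen-bond donor, a question that a naphthalen-2-yl group or a 1-methyl-1H-indol-3-yl group at this position would separate. Also open, on these data alone, is whether a methoxy group or a fluorine on the 1H-indol-3-yl ring would move the value further or lose it.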